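The compounds below may be only part of what the source reports. "The series", "measured", "known", "first", "only" and "open" are said of these compounds alone.

Measured in a functional assay on BGC-823 cells (Homo sapiens) for inhibition, read by CCK-8 assay, with a stated time of 48 h; a higher number here means a weaker inhibitor, a lower number a stronger inhibitor:

- compound 1 `Cc1ccc(C2=NN(C3=NC(=O)CS3)C(c3ccc4ccccc4c3)C2)cc1`: 7790 nM
- compound 2 `Fc1ccc(C2=NN(C3=NC(c4ccccc4)CS3)C(c3ccc4ccccc4c3)C2)cc1`: 17300 nM
- compound 3 `O=C1CSC(N2N=C(c3ccc(Br)cc3)CC2c2ccc3ccccc3c2)=N1`: 11700 nM

Compound 3, at 11700 nM, lies within the usual scatter of both compound 1 and compound 2, so these numbers give it no clear rank against either. The next compound, compound 4 `O=C1CSC(N2N=C(c3ccc(F)cc3)CC2c2ccc3ccccc3c2)=N1`, keeps the core of compound 3 and changes one substituent: fluoro in place of bromo on an aromatic carbon. In words, this is fluoro in place of bromo on an aromatic carbon, a change from 4-bromophenyl to 4-fluorophenyl.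

For the measured compounds named here, one measured step bears directly on this change. At the same place on the ring, bromo in place of methyl gave a 1.5-fold higher number from compound 1 to compound 3 (0.18 log units; within the scatter). Compound 2 also carries a fluoro group, but it differs from compound 3 in more than one place, so it offers no clean comparison. Going by the values given here, no measured compound yet shows the exchange of bromo for fluoro itself. Among the compounds with values here, with only that small step as a guide, no change beyond the scatter is expected in this assay, and no firm direction can be assigned. The expected change is a 1.2-fold lower number from compound 3 to compound 4 (0.07 log units; within the scatter). For compound 4 the estimated value is 10000 nM, with an expected range from 4500 nM to 22000 nM.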

Compound 4, half-maximal inhibitory concentration: 14900 nM
For compound 4 the middle estimate is 1.5-fold (0.17 log units) below the measured one; the range from low to high includes it.
By their numbers in this assay, from the lowest: compounds 1, 3, 4 and 2 (each within the scatter of the next, the first and the last beyond it).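

In this assay the direct exchange of bromo for fluoro at this position gives a 1.3-fold higher number from compound 3 to compound 4 (0.11 log units; within the scatter), and fluoro in place of methyl gives a 1.9-fold higher number from compound 1 to compound 4 (0.28 log units; within the scatter), so the 4-fluorophenyl group cannot be told apart from either of the other two substituents tested here. Together with the earlier methyl-to-bromo step, this closes the set of three pairs: methyl, bromo and fluoro at this place all lie within the scatter of one another on the shared core. For the compounds shown here, with fluoro held constant, the first clean comparison of the other varied place, the group on the amine nitrogen in a ring, gives a 1.2-fold lower number from compound 2 to compound 4 (0.06 log units; within the scatter), so that exchange also has no effect that these numbers can resolve.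

No supporting evidence is available to bear on these results. The compounds shown leave open whether an amine, a carboxylic acid or a longer chain at this aromatic carbon would give a step beyond the scatter, and whether the exchange on the ring nitrogen would read the same with bromo or methyl in place of fluoro.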